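Phenyl in place of difluorophenyl on the aromatic nitrogen

A few compounds are considered here, and "the series" means these few. Any claim that something is new, unique, unknown or untested is made for them only; others in the source may bear on it.

Compound 3 `Cc1c(C#N)cc(-c2ccc(S(C)(=O)=O)cc2)n1-c1ccc(F)c(F)c1` gives 57% in a functional assay on the whole organism (strain Swiss albino) for inhibition, with Mus musculus as the target, in the writhing test, with a stated time of 30 min, at a dose of 40 mg/kg by the oral route; a higher number here means a stronger effect of the compound at the dose given, a lower number a weaker effect. Compound 2 `Cc1c(/C=N\O)cc(-c2ccc(S(C)(=O)=O)cc2)n1-c1ccccc1` gives 57% in this assay, level with compound 3 at the digits shown, the two together the highest of the three numbers. Compound 1 `Cc1c(C=O)cc(-c2ccc(S(C)(=O)=O)cc2)n1-c1ccccc1` gives 30% in this assay, a number below that of compound 3 beyond the scatter. Going by the values given here, the one measured single-place step, a number 27 percentage points higher from compound 1 to compound 2 (beyond the scatter), concerns a group on an aromatic carbon of the shared core; no measured pair changes the group on the aromatic nitrogen.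

Compound 4 `Cc1c(C#N)cc(-c2ccc(S(C)(=O)=O)cc2)n1-c1ccccc1` differs from compound 3 by phenyl in place of 3,4-difluorophenyl on an aromatic nitrogen. Among the compounds with values here, nothing measured so far tells how the aryl on the aromatic nitrogen moves the number, so no step beyond the scatter is expected in either direction. The expected step is a number 5 percentage points lower from compound 3 to compound 4 (within the scatter) in this assay, inside the usual scatter. For compound 4 the estimate in this assay is 52%, with a range from 35% to 68%.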

Compound 4, a percentage reported as inhibition, in the whole organism at one dose (the size of the read-out at that dose, not a potency): 59%
Beside the measured number, compound 4's estimate is 7 percentage points below it; measured number inside the range.
By their numbers in this assay, from the lowest: compound 1; then compounds 2, 3 and 4 (each within the scatter of the next).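

In this assay, phenyl in place of 3,4-difluorophenyl on the aromatic nitrogen, with the cyano group held, gives a number 2 percentage points higher from compound 3 to compound 4 (within the scatter), so this first measured pair at the position shows that the two fluorines can be dropped without a step beyond the scatter. With phenyl held on the aromatic nitrogen, the group on the aromatic carbon still separates the compounds: cyano in place of formyl gives a number 29 percentage points higher from compound 1 to compound 4 (beyond the scatter), whereas cyano in place of the group of 3 heavy atoms gives a number 2 percentage points higher from compound 2 to compound 4 (within the scatter). No evidence on hand accounts for any of these numbers.

This reading of the aromatic nitrogen rests on a single pair at a single dose, with cyano on the aromatic carbon. As far as these compounds go, how a 4-methoxyphenyl or a cyclohexyl group on the aromatic nitrogen, or a carboxylic acid on the aromatic carbon, would read remains open.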